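The source may report more compounds than this note shows. Statements on the series, on what has been measured and on what is new or still open speak of the compounds shown alone.

In an assay on HEK293 cells for displacement of a labelled ligand from C-X-C chemokine receptor type 3 (Homo sapiens) (a lower number here means a stronger inhibitor, a higher number a weaker inhibitor), the measured compounds stand as follows.
Compound 1 `CN(CC1=CC[C@H]2C[C@@H]1C2(C)C)Cc1ccc(-c2cccc([N+](=O)[O-])c2)cc1` gives 2000 nM.
Compound 2 `CN(CC1=CC[C@H]2C[C@@H]1C2(C)C)Cc1ccc(-c2cccc(O)c2)cc1` gives only a limit, > 316 nM.
Compound 3 `CN(CC1=CC[C@H]2C[C@@H]1C2(C)C)Cc1ccc(-c2ccc(Cl)cc2)cc1` gives only a limit, > 316 nM.

Compound 3 thus stands at the limit of > 316 nM in this assay, at which 2 of the 3 values shown sit, without a number of its own. Compound 4 `CN(CC1=CC[C@H]2C[C@@H]1C2(C)C)Cc1ccc(-c2cc(Cl)cc(Cl)c2)cc1` differs from compound 3 in one place: 3,5-dichlorophenyl in place of 4-chlorophenyl on an aromatic carbon. The steps that reach compound 3 are a step that the limit leaves unreadable from compound 1 to compound 3 and a step that the two limits leave unreadable from compound 2 to compound 3, so neither tells how far compound 3 lies beyond its limit. Within the data shown here, no measured step speaks to the entry of a second chlorine itself. In this assay the expected step is a step that the limit leaves unreadable from compound 3 to compound 4, small. Compound 4 is estimated at 1500 nM, from 400 nM to 6000 nM, most likely again reported only as a limit.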

Compound 4, inhibition constant: > 316 nM
Compound 4: no number, only a limit; the forecaster's own chance of this, stated with the estimate: 60%; the middle value is on the limit's open side.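

In this assay compound 4 gives only a limit, > 316 nM, so its steps from compound 1, compound 2 and compound 3 cannot be read. The compounds shown leave open how far compound 2, compound 3 and compound 4 each lie beyond their limit, and what the second chlorine changes.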